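The source may report more compounds than this note shows. Statements on the series, on what has been measured and on what is new or still open speak of the compounds shown alone.

In an assay on isolated protein for inhibition of Calpain-1 catalytic subunit (Sus scrofa) (a lower number here means a stronger inhibitor, a higher number a weaker inhibitor), the three measured compounds stand as follows: compound 1 `O=C(O)/C(S)=C/c1c[nH]c2cc(Br)ccc12` gives 90 nM; compound 2 `O=C(O)/C(S)=C/c1c[nH]c2cc(I)ccc12` gives 300 nM; compound 3 `O=C(O)/C(S)=C/c1c[nH]c2ccc(I)cc12` gives 90 nM.

Compound 2 and compound 1 differ in one place, (bromo in place of iodo on an aromatic carbon), and that change made a 3.3-fold lower number from compound 2 to compound 1 (0.52 log units; beyond the scatter). Compound 3 is built from the same atoms as compound 2, joined differently; the difference between the two cores is not broken down here. At the digits given, compound 3 is level with compound 1, and together they show the lowest numbers of the three.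

Compound 4 `O=C(O)/C(S)=C/c1c[nH]c2ccc(Br)cc12` has not yet been measured in this assay. It is reached from compound 3 by the same change, (bromo in place of iodo on an aromatic carbon). Among the measured compounds shown here, the expected step is a 2.0-fold lower number from compound 3 to compound 4 (0.30 log units; within the scatter), an expectation that rests on the step seen because of a 3.3-fold lower number from compound 2 to compound 1 (0.52 log units; beyond the scatter), with only one such pair to lean on. For compound 4 in this assay the estimate is 45 nM, expected to fall between 15 nM and 130 nM.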

Compound 4, half-maximal inhibitory concentration: 20 nM
Compound 4: middle estimate off by 2.3-fold (0.35 log units), on the high side; the measured number falls inside the stated range.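

In this assay, bromo in place of iodo on an aromatic carbon gave a 4.5-fold lower number from compound 3 to compound 4 (0.65 log units; beyond the scatter). Set beside the earlier case, the change carried over from one core to the other with a similar size: the same change on two cores in this assay, a 3.3-fold lower number (0.52 log units; beyond the scatter) from compound 2 to compound 1 and a 4.5-fold lower number (0.65 log units; beyond the scatter) from compound 3 to compound 4, 1.4-fold (0.13 log units) apart, within the scatter of two such steps. This rests on two pairs in a single assay, so it does not show that the step would hold on a third core, and it does not explain why the bromo compounds give the lower numbers.

The compounds shown carry only bromo or iodo on the six-membered aromatic ring, which leaves open what chloro, fluoro or an amine would give there. Also open, from the compounds shown here alone, is how an ester in place of the carboxylic acid would fare.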